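From Methyl to Difluoromethoxy on the Shared Core

A few compounds are considered here, and "the series" means these few. Any claim that something is new, unique, unknown or untested is made for them only; others in the source may bear on it.

In a physicochemical assay for acid dissociation, read by spectrophotometry, at pH 2, compound 2 `Cc1cc(C)c(Nc2nc(Cl)cn([C@H](C)C3CC3)c2=O)c(C)n1` gives 7.9, the highest of the three numbers measured. Compound 1 `COc1cc(C)c(Nc2nc(Cl)cn([C@H](C)C3CC3)c2=O)c(C)n1` gives 3.8, and compound 3 `COc1nc(C)c(Nc2nc(Cl)cn([C@H](C)C3CC3)c2=O)cc1C`, which also carries a methoxy group, gives 3.6. Compound 4 `Cc1cc(OC(F)F)nc(C)c1Nc1nc(Cl)cn([C@H](C)C2CC2)c1=O` has difluoromethoxy in place of methyl on an aromatic carbon. Among the measured compounds shown here, the one measured step that bears on this change is methyl in place of methoxy, a number 4.10 log units higher from compound 1 to compound 2 (beyond the scatter), which is large and beyond the scatter. Read in reverse, it points downward on leaving methyl, although no difluoromethoxy compound has yet been measured. A large downward step is therefore expected, a number 5.60 log units lower from compound 2 to compound 4 (beyond the scatter). For compound 4 the estimate is 2.3, with an expected range from 1.2 to 3.4.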

Compound 4, acid dissociation constant: < 2
Compound 4 was reported as a limit; the forecaster's own chance of this, stated with the estimate: 10%; middle value at least 0.30 log units from the limit.
By their numbers in this assay, from the lowest: compounds 3 and 1 (each within the scatter of the next); then compound 2. At a limit, below all of these: compound 4.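

In this assay compound 4 is reported as a limit and not as a number: the limit of < 2 in this assay, at which 1 of the 4 values shown sits. At this position, next to the ring nitrogen, difluoromethoxy in place of methyl gives a number at least 5.90 log units lower from compound 2 to compound 4 (beyond the scatter). Difluoromethyl in place of methyl on the oxygen gives a number at least 1.80 log units lower from compound 1 to compound 4 (beyond the scatter), so the methoxy compounds do not mark the low end of the series at this position. From the compounds shown here alone, the full size of both steps stays open. So does the reading of this position with an amine or a trifluoromethoxy group in place of difluoromethoxy.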